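The source may report more compounds than this note shows. Statements on the series, on what has been measured and on what is new or still open speak of the compounds shown alone.

Measured compounds:
compound 1 `C#CCNC1CCc2c(SCc3cccc(F)c3)cccc21`: 1480 nM
compound 2 `C#CCNC1CCc2c(SCc3ccc(Br)cc3)cccc21`: 1310 nM
compound 3 `C#CCNC1CCc2c(SCCc3cccc(C(F)(F)F)c3)cccc21`: 3720 nM

All three were tested in an assay on isolated protein for inhibition of Amine oxidase [flavin-containing] B (Homo sapiens); on this read-out higher numbers stand for weaker inhibition and lower numbers for stronger inhibition. Compound 3 gives the highest number of the three, and its distance from compound 1 and from compound 2 lies beyond the usual scatter, so it is the weakest inhibitor among them. Compound 4 `C#CCNC1CCc2c(SCCc3cccc(OC)c3)cccc21` has not yet been measured. It differs from compound 3 in one place: methoxy in place of trifluoromethyl on an aromatic carbon, the ring itself and the two-carbon chain to the sulfur staying as they are.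

Within the data shown here, only one measured step speaks to a swap of the group on this ring. Going from compound 1 to compound 2, one ring substituent replaced another at a different position, and the result was a 1.1-fold lower number from compound 1 to compound 2 (0.05 log units; within the scatter). That pair carries a one-carbon link to the sulfur rather than the two-carbon chain of compound 3, so it is a loose guide, and it gives no direction for a trifluoromethyl-to-methoxy swap.

With a single step of this kind, and that one within the scatter, the expectation is that compound 4 changes little from compound 3: the estimated step is a 1.1-fold lower number from compound 3 to compound 4 (0.03 log units; within the scatter). Compound 4 is therefore estimated at 3500 nM, with a range from 1500 nM to 8000 nM.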

Compound 4, half-maximal inhibitory concentration: 28700 nM
Beside the measured number, compound 4's estimate is 8.2-fold (0.91 log units) below it; measured number above the stated range.
By their numbers in this assay, from the lowest: compounds 2 and 1 (each within the scatter of the next); then compound 3; then compound 4.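

In this assay, the group on this aromatic carbon clearly matters: methoxy in place of trifluoromethyl gives a 7.7-fold higher number from compound 3 to compound 4 (0.89 log units; beyond the scatter), a step beyond the scatter and so a real loss of inhibition. Among these compounds, the only earlier ring change, a 1.1-fold lower number from compound 1 to compound 2 (0.05 log units; within the scatter), stayed within the scatter, but it involved other groups on a one-carbon link, so it could not show how sensitive this ring position is on the two-carbon chain. The swap replaces a group of 4 heavy atoms with one of 2 and adds a hydrogen-bond acceptor, but no measurement shown here identifies which difference, if either, accounts for the higher number.

From the compounds shown here alone, it remains open whether the rise comes from losing trifluoromethyl or from adding methoxy, and a plain hydrogen, a chlorine or a hydroxyl on the same aromatic carbon would help separate the two. It is also unknown whether this swap would have a similar effect on a one-carbon link or on a longer chain to the sulfur.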